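The compounds below may be only part of what the source reports. "The series", "measured", "known", "first", "only" and "open" are said of these compounds alone.

Measured so far:
compound 1, `C=CCn1c(=O)/c(=C\c2ccccc2F)[nH]c(=O)/c1=C\c1ccccc1OC`: 23000 nM
compound 2, `C=CCn1c(=O)/c(=C\c2ccccc2C(F)(F)F)[nH]c(=O)/c1=C\c1ccccc1OC`: 6500 nM

For the measured compounds named here, in a functional assay on MCF7 cells (Homo sapiens) for cytotoxicity, read by CCK-8 assay, with a stated time of 72 h (on this read-out lower numbers stand for stronger inhibition and higher numbers for weaker inhibition), compound 2 gives 6500 nM, the lowest of the two numbers; compound 1, with 23000 nM, is its only neighbour, and the change between them was a 3.5-fold lower number from compound 1 to compound 2 (0.55 log units; beyond the scatter). Compound 3, `C=CCn1c(=O)/c(=C\c2cc(Br)ccc2F)[nH]c(=O)/c1=C\c1ccccc1OC`, has not yet been measured in this assay. It differs from compound 2 in one place: 5-bromo-2-fluorophenyl in place of 2-(trifluoromethyl)phenyl on a double-bonded chain carbon bound to an aromatic carbon.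

Going by the values given here, only one measured step speaks to this change, and only in part. The step from compound 1 to compound 2 showed that trifluoromethyl in place of fluoro gave a 3.5-fold lower number from compound 1 to compound 2 (0.55 log units; beyond the scatter). Among the compounds with values here, compound 3 goes back to fluoro at that place, so that gain would be expected to be given back; the bromine that enters has no counterpart among the measured compounds, and nothing here tells in which direction it pulls. Compound 3 is therefore expected to land near the higher number of compound 1, with wide uncertainty, a step of a 2.5-fold higher number from compound 2 to compound 3 (0.39 log units; beyond the scatter) being the estimate. For compound 3 the expected value in this assay is 16000 nM, within a range from 5000 nM to 50000 nM.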

Compound 3, half-maximal inhibitory concentration: 28100 nM
Beside the measured number, compound 3's estimate is 1.8-fold (0.24 log units) below it, and the stated range covers the measured number.
By their numbers in this assay, from the lowest: compound 2; then compounds 1 and 3 (each within the scatter of the next).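

In this assay, for the compounds shown here, the step of a 1.2-fold higher number from compound 1 to compound 3 (0.09 log units; within the scatter) lies within the scatter, so bromo in place of hydrogen on this aromatic ring makes no visible difference to the number, something the earlier compounds could not show because neither carried a bromine. The step of a 4.3-fold higher number from compound 2 to compound 3 (0.64 log units; beyond the scatter) lies beyond the scatter, which means that 5-bromo-2-fluorophenyl does not match 2-(trifluoromethyl)phenyl on the double-bonded chain carbon, and among these three compounds only the trifluoromethyl group gives a clearly lower number. Nothing measured here offers an explanation for the gap between these two groups.

The compounds shown cover only fluoro, trifluoromethyl and bromo on this ring, so it remains open whether an amine, a carboxylic acid or a nitrile there would lower the number further or raise it. Going by these compounds alone, it is also open whether bromo would stay just as silent on the 2-(trifluoromethyl)phenyl group of compound 2, where the number is already lower, since the only reading of bromo so far comes from the fluoro-bearing ring.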